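This account rests on a few compounds, and the source may have more. Where it says the series, first, only, none or still open, it means among the compounds named here.

Measured compounds:
Compound 1, `COc1ccc(S(=O)(=O)N2CCc3cccc(-c4ccc(F)nc4)c32)cc1`, gives 145 nM in a functional assay on MKN-45 cells (Homo sapiens) for inhibition, with a stated time of 72 h; a lower number here means a stronger inhibitor, a higher number a weaker inhibitor.
Compound 2, `COc1ccc(S(=O)(=O)N2CCc3cccc(-c4ccccc4)c32)cc1`, gives 117 nM in this assay.
Compound 3, `COc1ccc(S(=O)(=O)N2CCc3cccc(-c4ccc(O)cc4)c32)cc1`, gives 82.6 nM in this assay.

Compound 1 has the highest of the three numbers in this assay, but each neighbour sits within the scatter: a 1.2-fold lower number from compound 1 to compound 2 (0.09 log units; within the scatter) and a 1.8-fold lower number from compound 1 to compound 3 (0.24 log units; within the scatter). Compound 4, `COc1ccc(S(=O)(=O)N2CCc3cccc(-c4ccc(C#N)cc4)c32)cc1`, differs from compound 1 as follows: 4-cyanophenyl in place of 6-fluoropyridin-3-yl on an aromatic carbon. For the measured compounds named here, the steps that bear on this are the two exchanges of the same 6-fluoropyridin-3-yl for a phenyl, neither of which moved beyond the scatter, and the step of a 1.4-fold lower number from compound 2 to compound 3 (0.15 log units; within the scatter), which shows that a hydroxy on that phenyl also changed little. No step beyond the scatter is therefore expected in this assay. Compound 4 is estimated at 110 nM, with a range from 50 nM to 250 nM. That estimate corresponds to an expected 1.3-fold lower number from compound 1 to compound 4 (0.12 log units; within the scatter).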

Compound 4, half-maximal inhibitory concentration: 17.2 nM
Compound 4: the middle estimate sits 6.4-fold (0.81 log units) above what was measured; measured number below the stated range.
By their numbers in this assay, from the lowest: compound 4; then compounds 3, 2 and 1 (each within the scatter of the next).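

In this assay this aromatic carbon proved able to carry a change beyond the scatter: 4-cyanophenyl in place of 6-fluoropyridin-3-yl gives an 8.4-fold lower number from compound 1 to compound 4 (0.93 log units; beyond the scatter) and thus exceeds the earlier exchanges there. The substituent on the phenyl also matters, as cyano in place of hydrogen gives a 6.8-fold lower number from compound 2 to compound 4 (0.83 log units; beyond the scatter) and cyano in place of hydroxy gives a 4.8-fold lower number from compound 3 to compound 4 (0.68 log units; beyond the scatter) while hydroxy in place of hydrogen stayed within the scatter. Nothing measured here explains these steps. On these data alone, whether an amine, a carboxylic acid or an amide on that phenyl would behave like the cyano remains open.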